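Amide versus urea on a shared pyrazole core

The source may hold more compounds than are shown below. What is called first, only, known or untested is meant among the compounds shown, and "the series" means these compounds.

Compound 1 `COc1cc(-c2nn(-c3ccc(NC(=O)Nc4ccc(Cl)c(Cl)c4)cc3)cc2-c2ccncc2)ccc1Cl`, 3940 nM; compound 2 `COc1cc(-c2nn(-c3ccc(NC(=O)Nc4cc(C(F)(F)F)cc(C(F)(F)F)c4)cc3)cc2-c2ccncc2)ccc1Cl`, 1930 nM; compound 3 `COc1cc(-c2nn(-c3ccc(NC(=O)c4ccc(Cl)c(Cl)c4)cc3)cc2-c2ccncc2)ccc1Cl`, 40300 nM.

In a functional assay on SK-MEL-28 cells (Homo sapiens) for antiproliferative activity, read by sulforhodamine B assay, with a stated time of 48 h (a higher number here means a weaker inhibitor, a lower number a stronger inhibitor), compound 3 stands highest of the three, with compound 1 nearest and compound 2 furthest below it. Among the compounds with values here, the single step that reaches compound 3 is a 10-fold higher number from compound 1 to compound 3 (1.01 log units; beyond the scatter). Compound 4 `COc1cc(-c2nn(-c3ccc(NC(=O)c4ccc(Cl)c(C(F)(F)F)c4)cc3)cc2-c2ccncc2)ccc1Cl` differs from compound 3 by trifluoromethyl in place of chloro on an aromatic carbon. Within the data shown here, no measured step bears directly on this change; the nearest comparison is the pair compound 1 and compound 2, whose values differ only modestly, compound 2 giving the lower number. A small step is therefore expected, if any, toward a lower number, and the estimate for compound 4 is 25000 nM, spanning 8000 nM to 80000 nM, an expected step of a 1.6-fold lower number from compound 3 to compound 4 (0.21 log units; within the scatter).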

Compound 4, half-maximal inhibitory concentration: 2800 nM
Estimate against measurement, compound 4: 8.9-fold (0.95 log units) above, outside the stated range (below it).
By their numbers in this assay, from the lowest: compounds 2, 4 and 1 (each within the scatter of the next, the first and the last beyond it); then compound 3.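

In this assay, trifluoromethyl in place of chloro, ortho to a chloro group, proves a large change on the amide, with a 14-fold lower number from compound 3 to compound 4 (1.16 log units; beyond the scatter) as the step. The amide is therefore not weak in itself, for with the 4-chloro-3-(trifluoromethyl)phenyl group, a 1.4-fold lower number from compound 1 to compound 4 (0.15 log units; within the scatter) leaves it within the scatter of the urea. Nothing available here explains this gain.

As far as these compounds go, whether a nitrile, a methyl or a bromo at this position would match trifluoromethyl remains open. So does whether the same exchange would move the urea of compound 1 as far.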